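The source may hold more compounds than are shown below. What is called first, only, known or untested is meant among the compounds shown, and "the series" means these compounds.

Measured compounds:
- compound 1, `COc1ccc(/C=C/C(=O)c2cc(NC(C)=O)ccc2O)cc1`: in an ADME assay on MT4 cells (Homo sapiens) for cytotoxicity, read by MTT assay, with a stated time of 4 days (a higher number here means that more compound is tolerated, a lower number that less compound is tolerated), compound 1 gives 38700 nM
- compound 2, `CC(=O)Nc1ccc(O)c(C(=O)/C=C/c2ccc(F)cc2)c1`: in this assay compound 2 gives 41100 nM
- compound 3, `COc1ccccc1-c1oc2ccc(N)cc2c(=O)c1OC`: in this assay compound 3 gives 229000 nM

Compound 1 and compound 2 share a core and differ in one place: fluoro in place of methoxy on an aromatic carbon. The step is a 1.1-fold higher number from compound 1 to compound 2 (0.03 log units; within the scatter), so the two values show no difference that can be read.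

Compound 3 stands on a different core. The difference between the core of compound 3 and the core of compound 1 is not broken down here. Its value in this assay is the highest of the three, beyond the scatter from both compound 1 and compound 2.

Compound 4, `COc1c(-c2ccccc2F)oc2ccc(N)cc2c1=O`, has not yet been measured in this assay. It differs from compound 3 in one place: fluoro in place of methoxy on an aromatic carbon. Going by the values given here, this is the same kind of change as the one from compound 1 to compound 2, not the same one: in compound 2 the fluoro stands para to a large group, in compound 4 ortho to a large group.

The step from compound 3 to compound 4 in this assay is expected to be a 1.0-fold higher number from compound 3 to compound 4 (0.02 log units; within the scatter), close to the earlier step, because the earlier step was a 1.1-fold higher number from compound 1 to compound 2 (0.03 log units; within the scatter). This rests on a single pair on another core, so the range is kept wide. For compound 4 the estimate in this assay is 240000 nM, expected between 120000 nM and 480000 nM.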

Compound 4, half-maximal cytotoxic concentration: 234000 nM
For compound 4 the middle estimate is 1.0-fold (0.01 log units) above the measured one; the measured number falls inside the stated range.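

In this assay, fluoro in place of methoxy on an aromatic carbon, ortho to a large group, gives a 1.0-fold higher number from compound 3 to compound 4 (0.01 log units; within the scatter), so compound 3 and compound 4 cannot be told apart on this core. Set beside the earlier pair, the change leaves no readable mark on either core, and the two steps themselves cannot be told apart: the same change on two cores in this assay, a 1.1-fold higher number (0.03 log units; within the scatter) from compound 1 to compound 2 and a 1.0-fold higher number (0.01 log units; within the scatter) from compound 3 to compound 4, 1.0-fold (0.02 log units) apart, within the scatter of two such steps. Going by these compounds alone, this supports carrying the exchange between these two cores in this read-out as a change without a readable effect, but it rests on only two pairs and does not show that the same would hold on a third core, at another place on the ring, or in any other kind of measurement.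

What the compounds shown leave open is whether any group on this aromatic carbon moves the number at all, since methoxy and fluoro are the only two compared there. Chloro, trifluoromethyl, a nitrile or a longer chain such as ethoxy or propoxy on the same carbon would test this on both cores, and would show whether the flat result belongs to this one exchange or to the position as a whole.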